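Moving the Pyridine Nitrogen in Two Related Cores

This account rests on a few compounds, and the source may have more. Where it says the series, first, only, none or still open, it means among the compounds named here.

Compound 1 `CN1C/C(=C\c2cccnc2)C(=O)/C(=C/c2ccccc2C(F)(F)F)C1` gives 2910 nM in a functional assay on QGY-7703 cells (Homo sapiens) for cytotoxicity, read by MTT assay, with a stated time of 24 h; a lower number here means a stronger inhibitor, a higher number a weaker inhibitor. Compound 3 `CN1C/C(=C\c2ccncc2)C(=O)/C(=C/c2ccccc2C(F)(F)F)C1` carries pyridin-4-yl in place of pyridin-3-yl on a double-bonded chain carbon bound to a double-bonded ring carbon and gives 4500 nM in this assay; the step is a 1.5-fold higher number from compound 1 to compound 3 (0.19 log units; within the scatter). Compound 2 `CN1C/C(=C\c2ccc(C(F)(F)F)cc2)C(=O)/C(=C/c2cccnc2)C1` rests on a different core; how the two cores differ is not broken down here. In this assay compound 2 gives 1660 nM; its gap to compound 3 lies beyond the scatter, its gap to compound 1 within it. Compound 4 `CN1C/C(=C\c2ccncc2)C(=O)/C(=C/c2ccc(C(F)(F)F)cc2)C1` is not yet measured; it relates to compound 2 as compound 3 relates to compound 1, through (pyridin-4-yl in place of pyridin-3-yl on a double-bonded chain carbon bound to a double-bonded ring carbon), the same change at the same place. Because a 1.5-fold higher number from compound 1 to compound 3 (0.19 log units; within the scatter) stayed within the scatter, compound 4 is expected to show a 1.5-fold higher number from compound 2 to compound 4 (0.18 log units; within the scatter) in this assay. The estimate for compound 4 is 2500 nM, expected to fall between 1200 nM and 5500 nM.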

Compound 4, half-maximal inhibitory concentration: 10400 nM
For compound 4 the middle estimate is 4.2-fold (0.62 log units) below the measured one; the whole stated range lies below it.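

Changing pyridin-3-yl to pyridin-4-yl on a double-bonded chain carbon bound to a double-bonded ring carbon did not carry over unchanged in this assay: here the change gives a 6.3-fold higher number from compound 2 to compound 4 (0.80 log units; beyond the scatter). Set beside the earlier step, the result differs between the two cores: the same change on two cores in this assay, a 1.5-fold higher number (0.19 log units; within the scatter) from compound 1 to compound 3 and a 6.3-fold higher number (0.80 log units; beyond the scatter) from compound 2 to compound 4, 4.1-fold (0.61 log units) apart, beyond the scatter of two such steps. This shows that the size of this step in the series is not fixed across cores, but with one pair on each core it does not show which feature of the cores sets the two steps apart, or how the change would behave on a further core.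

The compounds shown leave open how a pyridin-2-yl group would compare with the two pyridines. They also leave open whether the gap between the steps would remain with a nitrile or a methoxy group in place of trifluoromethyl.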